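A few compounds are considered here, and "the series" means these few. Any claim that something is new, unique, unknown or untested is made for them only; others in the source may bear on it.

In an ADME assay on Huh7.5.1 cells (Homo sapiens) for cytotoxicity, read by ATP content, with a stated time of 48 h (on this read-out higher numbers stand for lower toxicity in this test and lower numbers for higher toxicity in this test), compound 1 `Cc1ccc(C)c(-c2nc(CN3CCC(C(=O)NCCCN4C[C@H](C)C[C@H](C)C4)CC3)c(C)o2)c1` gives 4070 nM, and compound 2 `Cc1oc(-c2ccccc2Cl)nc1CN1CCC(C(=O)NCCCN2C[C@H](C)C[C@H](C)C2)CC1` gives 16500 nM, the higher of the two numbers. Within the data shown here, only one measured step bears on what follows: a 4.1-fold higher number from compound 1 to compound 2 (0.61 log units; beyond the scatter), a modest change made at the same aromatic carbon. Compound 3 `Cc1oc(-c2c(Br)cccc2Br)nc1CN1CCC(C(=O)NCCCN2C[C@H](C)C[C@H](C)C2)CC1` alters compound 2 at that place, on an aromatic carbon of a five-membered aromatic ring with 1 nitrogen and 1 oxygen, with 2,6-dibromophenyl in place of 2-chlorophenyl on an aromatic carbon. Among the measured compounds shown here, no measured compound carries bromine, so the evidence is thin. The closest guide is compound 1, whose 2,5-dimethylphenyl, like the 2,6-dibromophenyl, bears two groups on the ring, and which stands at 4070 nM. A step of about that size or somewhat smaller is therefore expected, toward a lower number, although a single pair cannot establish a trend. The expected step is a 2.1-fold lower number from compound 2 to compound 3 (0.31 log units; beyond the scatter). For compound 3 the estimated value is 8000 nM, with an expected range from 2800 nM to 22000 nM.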

Compound 3, half-maximal cytotoxic concentration: 6500 nM
Compound 3: the middle estimate sits 1.2-fold (0.09 log units) above what was measured; the measured number falls inside the stated range.
By their numbers in this assay, from the lowest: compounds 1 and 3 (each within the scatter of the next); then compound 2.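

In this assay the exchange of 2-chlorophenyl for 2,6-dibromophenyl on this aromatic carbon gives a 2.5-fold lower number from compound 2 to compound 3 (0.40 log units; beyond the scatter), so a second change of the aryl group at this place also moves the number beyond the scatter. The other pair gives a 1.6-fold higher number from compound 1 to compound 3 (0.20 log units; within the scatter), which lies within the scatter, so 2,6-dibromophenyl and 2,5-dimethylphenyl cannot be told apart in this test even though one carries bromine and the other methyl groups. Among these three compounds, the two whose phenyl ring carries two groups, compound 1 and compound 3, sit together and compound 2, with its single chlorine, stands apart; none of the three goes against this, but it rests on very few compounds.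

Nothing available gives a reason for these differences. As far as these compounds go, it remains open whether a plain phenyl, a 2-bromophenyl or a 2,6-dichlorophenyl would follow the number of groups on the ring or the kind of atom, and whether a pyridine ring or a methoxy group at this place would fit the same picture.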